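Closing the open chain in compound 4

The source may hold more compounds than are shown below. What is called first, only, known or untested is meant among the compounds shown, and "the series" means these compounds.

Measured in a functional assay on A549 cells (Homo sapiens) for antiproliferative activity (a higher number here means a weaker inhibitor of growth, a lower number a stronger inhibitor of growth), three compounds on one shared core stand as follows: compound 1 `CC/C=C\[C@H](C)[C@H](OC(N)=O)[C@@H](C)[C@H](O)[C@@H](C)C/C(C)=C\[C@H](C)[C@@H](O)[C@@H](C)/C=C\[C@@H](O)C[C@H](O)[C@H](C)CO` gives 5000 nM while compound 2 `CC/C=C\[C@H](C)[C@H](OC(N)=O)[C@@H](C)[C@H](O)[C@@H](C)C/C(C)=C\[C@H](C)[C@@H](O)[C@@H](C)/C=C\[C@@H](O)C[C@H]1CCC(=O)O1` gives 63 nM and compound 3 `CC/C=C\[C@H](C)[C@H](OC(N)=O)[C@@H](C)[C@H](O)[C@@H](C)C/C(C)=C\[C@H](C)[C@@H](O)[C@@H](C)/C=C\[C@@H](O)C[C@H](O)[C@H](C)C[C@H](C)C(=O)OC` gives 4000 nM as its reading. Compound 3 therefore sits with the other open-chain compound and far from the ring-bearing one: the two steps are a 1.3-fold lower number from compound 1 to compound 3 (0.10 log units; within the scatter) and a 63-fold higher number from compound 2 to compound 3 (1.80 log units; beyond the scatter) and only the second lies beyond the scatter.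

Compound 4 `CC/C=C\[C@H](C)[C@H](OC(N)=O)[C@@H](C)[C@H](O)[C@@H](C)C/C(C)=C\[C@H](C)[C@@H](O)[C@@H](C)/C=C\[C@@H](O)C[C@@H]1OC(=O)NC[C@H]1C` is still unmeasured. Its change from compound 3 is this (a group of 8 heavy atoms (5 carbon, 1 nitrogen, 2 oxygen; one six-membered non-aromatic ring with 2 hetero atoms) in place of a group of 11 heavy atoms (8 carbon, 3 oxygen; no ring), on a saturated chain carbon, two bonds along the chain from a double-bonded chain carbon and an oxygen on a saturated carbon). The closest evidence is a 79-fold lower number from compound 1 to compound 2 (1.90 log units; beyond the scatter) in which a group with one five-membered non-aromatic ring with 1 hetero atom replaced an open chain. Among the measured compounds shown here, compound 2 is the only measured compound with a ring at this place, while compounds 1 and 3 have none there. For the measured compounds named here, the ring of compound 4 is a different one, a six-membered non-aromatic ring with 2 hetero atoms, and no measured compound carries it, so only part of that large step is expected. In this assay the expected move is a 13-fold lower number from compound 3 to compound 4 (1.12 log units; beyond the scatter) as an estimate, toward a lower number. For compound 4 the estimated value is 300 nM with an expected range from 60 nM to 2000 nM in this measurement.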

Compound 4, concentration for 50% growth inhibition: 1000 nM
Estimate against measurement, compound 4: 3.3-fold (0.52 log units) below; measured number inside the range.
By their numbers in this assay, from the lowest: compound 2; then compound 4; then compounds 3 and 1 (each within the scatter of the next).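

In this assay, the drop in number on moving from an open chain to a ring at this place no longer rests on compound 2 alone, since the six-membered non-aromatic ring with 2 hetero atoms also stands apart from both open-chain compounds, with a 4.0-fold lower number from compound 3 to compound 4 (0.60 log units; beyond the scatter) and a 5.0-fold lower number from compound 1 to compound 4 (0.70 log units; beyond the scatter). The ring's identity also counts, as a 16-fold higher number from compound 2 to compound 4 (1.20 log units; beyond the scatter) puts the two ring-bearing compounds clearly apart, so among these four compounds a ring at this place lowers the number but the new ring reaches only part of what the five-membered ring with 1 hetero atom reaches. Nothing measured here accounts for the gap between the two rings.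

Compound 2 and compound 4 differ at once in ring size and in the hetero atoms of the ring, and the compounds shown cannot separate these two changes. They also leave open how a six-membered non-aromatic ring with 1 hetero atom, an amine or a carboxylic acid would read on this saturated chain carbon.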